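The source may hold more compounds than are shown below. What is called first, only, known or untested is meant among the compounds shown, and "the series" means these compounds.

Among the compounds with values here, compound 3 `CC(C)(C)c1ccc(C(=O)N2CCC3(CC2)C(=O)N(CC(=O)NCCCCN)CN3c2ccccc2)cc1` gives the highest of the three numbers measured so far: in an assay on HEK293 cells for displacement of a labelled ligand from NPC1-like intracellular cholesterol transporter 1 (Homo sapiens) (on this read-out lower numbers stand for stronger inhibition and higher numbers for weaker inhibition), compound 3 gives 14500 nM. Compound 1 `CC(C)(C)c1ccc(C(=O)N2CCC3(CC2)C(=O)N(CC(=O)N2CCCC(O)C2)CN3c2ccccc2)cc1`, with a 3-hydroxypiperidin-1-yl on the carbonyl carbon, gives 12200 nM, and compound 2 `CCC1CCCN(C(=O)CN2CN(c3ccccc3)C3(CCN(C(=O)c4ccc(C(C)(C)C)cc4)CC3)C2=O)C1`, with a 3-ethylpiperidin-1-yl there, gives 3900 nM. The two steps that end at compound 3 both change the group on that carbonyl carbon: a 1.2-fold higher number from compound 1 to compound 3 (0.08 log units; within the scatter), while a 3.7-fold higher number from compound 2 to compound 3 (0.57 log units; beyond the scatter). Between the two piperidines, a 3.1-fold lower number from compound 1 to compound 2 (0.50 log units; beyond the scatter).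

Compound 4 `CC(C)(C)c1ccc(C(=O)N2CCC3(CC2)C(=O)N(CC(=O)NCCCNS(C)(=O)=O)CN3c2ccccc2)cc1` differs from compound 3 by methanesulfonamido in place of aminomethyl on a saturated chain carbon, three bonds along the chain from an amide-type nitrogen. The changes at this carbonyl carbon seen so far range from none beyond the scatter to a modest shift, so a step of at most modest size is expected for a 1.5-fold lower number from compound 3 to compound 4 (0.16 log units; within the scatter), with the direction uncertain. On that basis compound 4 is estimated to give 10000 nM in this assay, with a range from 3000 nM to 40000 nM.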

Compound 4, half-maximal inhibitory concentration: 10400 nM
For compound 4 the middle estimate is 1.0-fold (0.02 log units) below the measured one; low and high end bracket the measured number.
By their numbers in this assay, from the lowest: compound 2; then compounds 4, 1 and 3 (each within the scatter of the next).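

Swapping aminomethyl for methanesulfonamido on this saturated chain carbon, three bonds along the chain from an amide-type nitrogen, gives a step within the scatter in this assay (a 1.4-fold lower number from compound 3 to compound 4 (0.14 log units; within the scatter)), so this end of the chain accepts a larger group carrying sulfur and two oxygens with no readable change. Compound 4 also stays within the scatter of the hydroxylated piperidine (a 1.2-fold lower number from compound 1 to compound 4 (0.07 log units; within the scatter)), while compound 2, with its 3-ethylpiperidin-1-yl, still gives a lower number than this new chain (a 2.7-fold higher number from compound 2 to compound 4 (0.43 log units; beyond the scatter)). Nothing in the data shown accounts for these results.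

On these data alone, it remains open whether a carboxylic acid or an acetamido at the same chain end would move the number beyond the scatter. A longer chain carrying methanesulfonamido, or a propyl in place of the ethyl on the piperidine, is equally unsettled.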